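Aryl ether change from compound 1 to compound 3

This account rests on a few compounds, and the source may have more. Where it says the series, first, only, none or still open, it means among the compounds named here.

Two compounds of this series have numbers in a functional assay on HCT-116 cells (Homo sapiens) for antiproliferative activity, read by MTT assay, with a stated time of 72 h; on this read-out lower numbers stand for stronger inhibition and higher numbers for weaker inhibition. Compound 1 `NC1=NC2(CCOCC2)N(OCCCOc2cccc(Cl)c2Cl)C(N)=N1` gives 5 nM and compound 2 `NC1=NC2(CCSCC2)N(OCCCOc2cc(Cl)c(Cl)cc2Cl)C(N)=N1` gives 1 nM. Compound 1 thus stands at the higher of the two numbers, with compound 2 below it by a gap beyond the scatter; the two compounds differ in more than one place, so only their values are set side by side here.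

Compound 3 `NC1=NC2(CCOCC2)N(OCCCOc2ccc(Br)cc2)C(N)=N1` has not yet been measured. It differs from compound 1 in one place: 4-bromophenyl in place of 2,3-dichlorophenyl on an oxygen on a saturated carbon. Within the data shown here, both measured compounds carry chlorine-bearing aryl ethers, whereas compound 3 carries 4-bromophenyl at the same place; nothing measured shows how such an exchange bears on the read-out, and no step between measured compounds is available. The step is expected to be a moderate move toward a higher number, a 3.0-fold higher number from compound 1 to compound 3 (0.48 log units; beyond the scatter), of a size near the edge of the scatter. Compound 3 is estimated at 15 nM, with a range from 4 nM to 60 nM.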

Compound 3, half-maximal inhibitory concentration: 320 nM
Compound 3: the middle estimate sits 21-fold (1.33 log units) below what was measured, outside the stated range (above it).
By their numbers in this assay, from the lowest: compound 2; then compound 1; then compound 3.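

In this assay, among these compounds, the aryl group on the oxygen on a saturated carbon gives the first readable step: 4-bromophenyl in place of 2,3-dichlorophenyl produces a 64-fold higher number from compound 1 to compound 3 (1.81 log units; beyond the scatter), with the rest of compound 1 unchanged. The read-out is thus clearly sensitive to this exchange, even though both groups have a six-membered aromatic ring of carbon only, neither has hydrogen-bond donors or acceptors, and neither carries a net charge; what differs is the halogen substitution on that ring. Among the compounds shown here, nothing measured so far speaks to what lies behind a step of this size.

Halogen type, number and ring location all change together in this single step, so it remains open which of them accounts for the higher number. Setting 4-chlorophenyl and 2,3-dibromophenyl at the same place against compound 1 and compound 3 would separate these changes, while unsubstituted phenyl would show how the series reads without any halogen on the ring.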